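The source may hold more compounds than are shown below. What is called first, only, known or untested is meant among the compounds shown, and "the series" means these compounds.

Of the compounds shown here, three from this study have been tested in a toxicity assay on RAW264.7 cells (Mus musculus) for cytotoxicity, read by MTT assay, with a stated time of 24 h; a higher number here means a weaker inhibitor, a lower number a stronger inhibitor. Compound 1, `C=C[C@@](C)(/C=C/c1ccc(OCc2cn(-c3ccc(Cl)cc3)nn2)cc1)CCC=C(C)C`, gives 47600 nM. Compound 2, `C=C[C@@](C)(/C=C/c1ccc(OCc2cn(-c3ccc(F)cc3)nn2)cc1)CCC=C(C)C`, gives 233000 nM. Among the measured compounds shown here, the single change between them is fluoro in place of chloro on an aromatic carbon, and the resulting step is a 4.9-fold higher number from compound 1 to compound 2 (0.69 log units; beyond the scatter). Compound 3, `C=C[C@@](C)(/C=C/c1ccc(OC(=O)c2cn(-c3ccc(Cl)cc3)nn2)cc1)CCC=C(C)C`, gives 115000 nM in this assay; the difference between the core of compound 1 and the core of compound 3 is not broken down here.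

Compound 4, `C=C[C@@](C)(/C=C/c1ccc(OC(=O)c2cn(-c3ccc(F)cc3)nn2)cc1)CCC=C(C)C`, has not yet been measured in this assay. It differs from compound 3 by fluoro in place of chloro on an aromatic carbon, the same change that turns compound 1 into compound 2. For the measured compounds named here, with only one earlier example of this change, the expectation rests on that pair alone: because the step of a 4.9-fold higher number from compound 1 to compound 2 (0.69 log units; beyond the scatter) was a weakening of cytotoxicity beyond the usual scatter, a step of similar direction and size is expected here, so that the step from compound 3 to compound 4 is estimated as a 3.0-fold higher number from compound 3 to compound 4 (0.48 log units; beyond the scatter). On that basis compound 4 is expected to give about 350000 nM in this assay, with a likely range from 120000 nM to 1000000 nM.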

Compound 4, half-maximal inhibitory concentration: 79900 nM
Compound 4: middle estimate off by 4.4-fold (0.64 log units), on the high side; the measured number lies below the stated range.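

In this assay, fluoro in place of chloro on the core of compound 3 gives a 1.4-fold lower number from compound 3 to compound 4 (0.16 log units; within the scatter), so on this core the two compounds cannot be told apart. The same change therefore did not carry over from one core to the other, and the two steps differ by more than repeated measurements would normally explain: the same change on two cores in this assay, a 4.9-fold higher number (0.69 log units; beyond the scatter) from compound 1 to compound 2 and a 1.4-fold lower number (0.16 log units; within the scatter) from compound 3 to compound 4, 7.0-fold (0.85 log units) apart, beyond the scatter of two such steps. Among the compounds shown here, this shows that the step seen on the core of compound 1 cannot be used as a general rule for this series, but with only one pair on each core it does not show why the cores differ or which step is more typical.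

The compounds shown leave open what other groups at this place, such as bromo, methoxy or trifluoromethyl, would do on either core. They also leave open what the same change would do on a third core, such as one carrying an amide where compound 3 carries its ester.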